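The source may hold more compounds than are shown below. What is called first, only, known or untested is meant among the compounds shown, and "the series" means these compounds.

Measured so far in a functional assay on 1321-N1 cells for agonist activity at P2Y purinoceptor 2 (Homo sapiens), read by scintillation counting and inositol phosphate accumulation; a higher number here means that more compound is needed for the effect, a lower number that less compound is needed:
compound 1 `O=c1[nH]/c(=N\OCCCc2ccc(Br)cc2)ccn1[C@@H]1O[C@H](COP(=O)(O)OP(=O)(O)OP(=O)(O)O)[C@@H](O)[C@H]1O` gives 350 nM;
compound 2 `O=c1[nH]/c(=N\OCCCc2ccc([N+](=O)[O-])cc2)ccn1[C@@H]1O[C@H](COP(=O)(O)OP(=O)(O)OP(=O)(O)O)[C@@H](O)[C@H]1O` gives 458 nM.

Compound 2 stands highest of these two numbers, the nearest being compound 1: a 1.3-fold higher number from compound 1 to compound 2 (0.12 log units; within the scatter), a difference within the scatter. Compound 3 `C#CCCNC(=O)COc1ccc(CCCO/N=c2/ccn([C@@H]3O[C@H](COP(=O)(O)OP(=O)(O)OP(=O)(O)O)[C@@H](O)[C@H]3O)c(=O)[nH]2)cc1` differs from compound 2 by a group of 9 heavy atoms (6 carbon, 1 nitrogen, 2 oxygen; no ring) in place of a group of 3 heavy atoms (1 nitrogen, 2 oxygen; no ring), on an aromatic carbon. Among the measured compounds shown here, the only measured step at that ring position, a 1.3-fold higher number from compound 1 to compound 2 (0.12 log units; within the scatter), exchanged one small substituent for another and stayed within the scatter; no measured step covers a group of the size entering here. With that thin basis, no step beyond the scatter is expected for compound 3 in this assay. Compound 3 is therefore estimated at 400 nM, with a range of 130 nM to 1300 nM, which means an expected step of a 1.1-fold lower number from compound 2 to compound 3 (0.06 log units; within the scatter).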

Compound 3, half-maximal effective concentration: 109 nM
For compound 3 the middle estimate is 3.7-fold (0.56 log units) above the measured one, and the stated range ends above it.
By their numbers in this assay, from the lowest: compound 3; then compounds 1 and 2 (each within the scatter of the next).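

In this assay, among the compounds shown here, the group of 9 heavy atoms on this aromatic carbon, para to a large group, gives the first steps beyond the scatter (a 4.2-fold lower number from compound 2 to compound 3 (0.62 log units; beyond the scatter)) and (a 3.2-fold lower number from compound 1 to compound 3 (0.51 log units; beyond the scatter)). The position therefore accepts a much larger group with no ring than nitro or bromo, and the number falls rather than rises. Nothing measured here bears on the reason for this step.

Which part of the entering group carries the step remains open, as the amide and the triple bond are not separated. Also open, on these data alone, is how a carboxylic acid, an amine or a longer chain at this carbon would compare.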